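From Fluoro to Nitro: Expected Cytotoxicity of Compound 4

The source may hold more compounds than are shown below. What is called first, only, known or untested is meant among the compounds shown, and "the series" means these compounds.

Of the compounds shown here, three sharing one core have been measured for cytotoxicity. Compound 1 `Cn1cc([N+](=O)[O-])cc1C(=O)NNC(=O)NCc1ccco1` in an ADME assay on Vero cells (Chlorocebus sabaeus) for cytotoxicity, read by MTT assay, with a stated time of 72 h (on this read-out higher numbers stand for weaker inhibition and lower numbers for stronger inhibition), gives 482000 nM. Compound 2 `Cn1cc([N+](=O)[O-])cc1C(=O)NNC(=S)Nc1ccc(Cl)cc1` gives 210000 nM in this assay, and compound 3 `Cn1cc([N+](=O)[O-])cc1C(=O)NNC(=S)Nc1ccc(F)cc1` gives 662000 nM in this assay. Compound 3 holds the highest of the three numbers; its nearest neighbour is compound 1, whose number lies within the scatter of that of compound 3, while compound 2 lies furthest, the step of a 3.2-fold higher number from compound 2 to compound 3 (0.50 log units; beyond the scatter) being beyond the scatter.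

Compound 4 `Cn1cc([N+](=O)[O-])cc1C(=O)NNC(=S)Nc1ccc([N+](=O)[O-])cc1` is not yet measured. It differs from compound 3 in one place: nitro in place of fluoro on an aromatic carbon. Going by the values given here, only one measured step touches this position on the ring, the step of a 3.2-fold higher number from compound 2 to compound 3 (0.50 log units; beyond the scatter), which is modest. Among the compounds with values here, no measured compound carries a nitro on this ring, so the expectation rests on the modest size of that single step and on the narrow spread of the three numbers. Compound 4 is expected in this assay to show a step of about a 1.7-fold lower number from compound 3 to compound 4 (0.22 log units; within the scatter), no larger than modest and uncertain in direction. The estimate for compound 4 is 400000 nM, with a range from 130000 nM to 1200000 nM.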

Compound 4, half-maximal inhibitory concentration: 395000 nM
Estimate against measurement, compound 4: 1.0-fold (0.01 log units) above; measured number inside the range.
By their numbers in this assay, from the lowest: compounds 2, 4, 1 and 3 (each within the scatter of the next, the first and the last beyond it).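

In this assay, the steps of a 1.7-fold lower number from compound 3 to compound 4 (0.22 log units; within the scatter) and a 1.9-fold higher number from compound 2 to compound 4 (0.27 log units; within the scatter) both lie within the scatter, so compound 4 cannot be told apart from either halogen-bearing compound, even though the step of a 3.2-fold higher number from compound 2 to compound 3 (0.50 log units; beyond the scatter) lies beyond it. Going by these compounds alone, on this aromatic carbon, para to a large group, the exchange of fluoro, with its single heavy atom and no hydrogen-bond acceptors, for nitro, with three heavy atoms and two hydrogen-bond acceptors, therefore brings no step beyond the scatter, and the only such step at this position remains the one between chloro and fluoro. Nothing available bears on what lies behind these numbers.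

The compounds shown leave open whether an amine, a carboxylic acid or a methoxy group on this same aromatic carbon would also stay within the scatter of these compounds, or whether a ring with only hydrogen there would. They also leave open what the other parts of the molecule contribute, since compound 1 differs from the other compounds in more than one place and offers no clean comparison with them.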